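Series notes: aryl substituent exchange from compound 2 to compound 4

This account rests on a few compounds, and the source may have more. Where it says the series, first, only, none or still open, it means among the compounds named here.

Compound 1 `COc1ccc(S(=O)(=O)N2CCC(CCC(=O)c3cc(Cl)c(N)cc3OC)CC2)cc1` gives "not determined" (no result reported) in an assay on brain for displacement of a labelled ligand from 5-hydroxytryptamine receptor 4 (Cavia porcellus), with a stated time of 30 min, in the presence of a further agent that is not named here (on this read-out lower numbers stand for stronger inhibition and higher numbers for weaker inhibition), that is, no result. Compound 2 `COc1ccc(S(=O)(=O)NCCN2CCC(CCC(=O)c3cc(Cl)c(N)cc3OC)CC2)cc1Br` gives 24.3 nM in this assay and stands highest of the two numbers measured there. Its nearest neighbour, compound 3 `COc1ccc(S(=O)(=O)NCCN2CCC(CCC(=O)c3cc(Cl)c(N)cc3OC)CC2)cc1`, gives 12.3 nM in this assay, and the step of a 2.0-fold lower number from compound 2 to compound 3 (0.30 log units; within the scatter) lies within the scatter. Compound 4 `COc1ccc(S(=O)(=O)NCCN2CCC(CCC(=O)c3cc(Cl)c(N)cc3OC)CC2)cc1OC` differs from compound 2 by methoxy in place of bromo on an aromatic carbon. Within the data shown here, the only measured step bearing on this change, the bromo-to-hydrogen exchange at the same aromatic carbon, was within the scatter, so no shift beyond the scatter is expected in this assay for a second replacement there. Compound 4 is therefore estimated at 18 nM, with a range of 6 nM to 55 nM. The expected step is a 1.4-fold lower number from compound 2 to compound 4 (0.13 log units; within the scatter).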

Compound 4, inhibition constant: 8.2 nM
Compound 4: middle estimate off by 2.2-fold (0.34 log units), on the high side; the range from low to high includes it.
By their numbers in this assay, from the lowest: compounds 4, 3 and 2 (each within the scatter of the next, the first and the last beyond it).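

Among these compounds, at the aromatic carbon that carries bromo in compound 2, methoxy gives the first step beyond the scatter at this position in this assay, a 3.0-fold lower number from compound 2 to compound 4 (0.47 log units; beyond the scatter), although the exchange of bromo for hydrogen had stayed within it. Methoxy does not separate from hydrogen at the same carbon, a 1.5-fold lower number from compound 3 to compound 4 (0.18 log units; within the scatter), so the three groups do not resolve into a clear order. No evidence is available to account for these steps.

Still open, going by these compounds, is whether ethoxy or an amine at this carbon would read like methoxy or like bromo. On these data alone, whether the bromo-to-methoxy step holds outside this pair is also open.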